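Series notes: loss of the chloro group from compound 1

This account rests on a few compounds, and the source may have more. Where it says the series, first, only, none or still open, it means among the compounds named here.

Measured so far:
compound 1, `COc1cc(OC)c(C(=O)/C=C/c2ccc(Cl)cc2)c(OC)c1`: 2.1%
compound 2, `COc1cc(O)c(C(=O)/C=C/c2ccccc2SC)c(OC)c1`: "not active" (no number reported)

For the measured compounds named here, compound 1 holds the only number; in a functional assay on MDA-MB-231 cells (Homo sapiens), read by fluorescence and BrdU incorporation, with a stated time of 48 h, tested at 25 uM (a higher number here means a weaker effect of the compound at the concentration tested, a lower number a stronger effect), compound 1 gives 2.1%, a strong effect at the concentration tested. Compound 2 is reported in this assay only as "not active" (no number reported), without a number. Compound 3, `COc1cc(OC)c(C(=O)/C=C/c2ccccc2)c(OC)c1`, differs from compound 1 by hydrogen in place of chloro on an aromatic carbon. Going by the values given here, no measured pair shows this kind of change, so the step is expected to weaken the effect moderately, beyond the scatter, while keeping a clear effect; the estimated step is a number 12.9 percentage points higher from compound 1 to compound 3 (beyond the scatter). Compound 3 is estimated at 15%, between 2% and 50%.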

Compound 3, a percentage reported as activity, at one concentration (the size of the read-out at that concentration, not a potency): 23%
Beside the measured number, compound 3's estimate is 8 percentage points below it; low and high end bracket the measured number.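

In this assay, for the compounds shown here, hydrogen in place of chloro on this aromatic carbon gives a number 20.9 percentage points higher from compound 1 to compound 3 (beyond the scatter) and supplies the first measured step. The position therefore responds to this change, yet compound 3 at 23% still shows a clear effect, so the chloro group is not required for activity. No available evidence bears on the origin of this step.

Only chloro and hydrogen can be compared at this position. As far as these compounds go, whether fluoro, bromo, methoxy or an amine would match chloro, or fall nearer hydrogen, remains open.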